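The source may report more compounds than this note shows. Statements on the series, on what has been measured and on what is new or still open speak of the compounds shown alone.

Working notes on the series. In a functional assay on CHO-K1 cells for antagonist activity at adenosine receptor A1 (Homo sapiens), read by a beta-galactosidase reporter and cAMP accumulation, with stated times of 15 min and 6 h (on this read-out higher numbers stand for weaker inhibition and lower numbers for stronger inhibition), compound 1 `Cc1ccc(-c2nc(N)c3cc(Cc4ccccc4)sc3n2)o1` gives 298 nM. Compound 2 `Nc1nc(-c2cnco2)nc2sc(Cc3ccccc3)cc12` gives 106 nM, and compound 3 `Nc1nc(-c2cccnc2)nc2sc(Cc3ccccc3)cc12` gives 1420 nM. Compound 3 stands highest of the three numbers: the step of a 4.8-fold higher number from compound 1 to compound 3 (0.68 log units; beyond the scatter) and the step of a 13-fold higher number from compound 2 to compound 3 (1.13 log units; beyond the scatter) both run upward to it, while the step of a 2.8-fold lower number from compound 1 to compound 2 (0.45 log units; beyond the scatter) runs the other way. All three steps exchange one aromatic ring for another on the shared core; every one of them is beyond the scatter.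

Compound 4 `N#Cc1cncc(-c2nc(N)c3cc(Cc4ccccc4)sc3n2)c1` keeps the ring of compound 3 and carries one extra group: cyano in place of hydrogen on an aromatic carbon. Within the data shown here, none of the measured steps adds a substituent to a ring that is kept; each swaps the ring itself, so no step bears directly on the change from compound 3 to compound 4. Among the measured compounds shown here, the measured steps say only that a change at this position of the core can move the number in this assay by a modest to large amount in either direction. With nothing to fix a direction, the expectation for compound 4 is a step of a 1.2-fold lower number from compound 3 to compound 4 (0.07 log units; within the scatter), that is, no step beyond the scatter, with a wide range. Compound 4 is therefore estimated at 1200 nM, between 400 nM and 4000 nM.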

Compound 4, inhibition constant: 1160 nM
Compound 4: middle estimate off by 1.0-fold (0.01 log units), on the high side; low and high end bracket the measured number.
By their numbers in this assay, from the lowest: compound 2; then compound 1; then compounds 4 and 3 (each within the scatter of the next).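

In this assay, among these compounds, this is the first change that adds a group to a ring that is kept rather than exchanging the ring, and the step is within the scatter (a 1.2-fold lower number from compound 3 to compound 4 (0.09 log units; within the scatter)), so cyano in place of hydrogen on this carbon, two atoms from the ring nitrogen, leaves the read-out without a resolvable change. The steps from the other two ring types stay beyond the scatter and are of similar size to those already seen for pyridin-3-yl (an 11-fold higher number from compound 2 to compound 4 (1.04 log units; beyond the scatter)) and (a 3.9-fold higher number from compound 1 to compound 4 (0.59 log units; beyond the scatter)), so among the compounds shown, the large moves go with exchanging the ring itself, and the one added group does not shift that picture. No measurement at hand explains why the cyano group leaves the number where it stands.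

Going by these compounds, whether this carbon tolerates other groups equally, such as an amine, a carboxylic acid, a methoxy group or a longer chain, stays open, since a single group cannot show a trend. Also open, on these data alone, is whether a cyano group on the 1,3-oxazol-5-yl ring, or on another carbon of the pyridin-3-yl ring, would be as silent in this assay as it is here.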